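The source may hold more compounds than are shown below. What is called first, only, known or untested is meant among the compounds shown, and "the series" means these compounds.

Measured compounds:
compound 1 `CCCCCCn1cnc2c(Nc3ccc(O)cc3)nc(N[C@H]3CC[C@H](N)CC3)nc21`, 7700 nM
compound 2 `CCCCCCn1cnc2c(Nc3cccc(Cl)c3)nc(N[C@H]3CC[C@H](N)CC3)nc21`, 5100 nM
compound 3 `CCCCn1cnc2c(Nc3ccc(Cl)cc3)nc(N[C@H]3CC[C@H](N)CC3)nc21`, 7300 nM

All three were tested in a functional assay on BT-474 cells (Homo sapiens) for inhibition, read by fluorescence, with a stated time of 72 h; on this read-out higher numbers stand for weaker inhibition of growth and lower numbers for stronger inhibition of growth. In this assay compound 2 gives 5100 nM, and both other numbers sit within the usual scatter of it, so none of the three can be set apart from the rest. Going by the values given here, the one step measured so far, the exchange of the aryl group, is a 1.5-fold lower number from compound 1 to compound 2 (0.18 log units; within the scatter) and does not move the number beyond the scatter. Compound 2 and compound 3 differ in two places at once, so their two values can only be read side by side: neither stands out.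

Compound 4 `CC(C)=CCn1cnc2c(Nc3cccc(Cl)c3)nc(N[C@H]3CC[C@H](N)CC3)nc21` is the next compound to be measured in this assay. It is made from compound 2 by the change (2-methylprop-1-en-1-yl in place of pentyl on a saturated chain carbon bound to an aromatic nitrogen). Among the compounds with values here, no measured step touches the chain on the aromatic nitrogen, so nothing in the data speaks for a shift in either direction. The aryl step, the only one known, stayed within the scatter, which suggests the core tolerates small changes without large effects. The expectation is therefore a step of about a 1.0-fold lower number from compound 2 to compound 4 (0.01 log units; within the scatter), that is, none beyond the scatter. Compound 4 is expected to give about 5000 nM in this assay, with a likely range from 2000 nM to 12000 nM.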

Compound 4, concentration for 50% growth inhibition: 7000 nM
Compound 4: the middle estimate sits 1.4-fold (0.15 log units) below what was measured; measured number inside the range.
By their numbers in this assay, from the lowest: compounds 2, 4, 3 and 1 (each within the scatter of the next).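

In this assay, going by these compounds alone, this is the first measured change to the chain on the aromatic nitrogen: 2-methylprop-1-en-1-yl in place of pentyl gives a 1.4-fold higher number from compound 2 to compound 4 (0.14 log units; within the scatter). Within the data shown here, the earlier compounds showed only that changing the aryl group left the number within the scatter, and this pair now shows the same for one change at this second site, even though the new group brings in a double bond outside aromatic rings and the chain is no longer straight. No measurement given here offers an explanation for this result.

A single step cannot separate the parts of this change, so a saturated 3-methylbut-1-yl group on the same nitrogen would be needed to tell the double bond apart from the branching. From the compounds shown here alone, it also remains open whether a much longer chain such as decyl, a benzyl group, or a chain ending in an amine or a carboxylic acid would move the number in this assay beyond the scatter.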